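The source may hold more compounds than are shown below. What is called first, only, known or untested is meant among the compounds shown, and "the series" means these compounds.

Measured so far in an assay on membranes from brain for displacement of a labelled ligand from Sigma non-opioid intracellular receptor 1 (Cavia porcellus), read by scintillation counting, with a stated time of 120 min; a higher number here means a weaker inhibitor, a lower number a stronger inhibitor:
compound 1 `CN(C)CC[C@H]1CCC[C@@H](c2ccccc2)C1`: 10 nM
compound 2 `NCC[C@H]1CCC[C@@H](c2ccccc2)C1`: 138 nM
compound 3 `NCC[C@@H]1CCC[C@H](c2ccccc2)C1`: 167 nM

Compounds 2 and 3 share everything but configuration; the difference is the two compounds have the same atoms and bonds and differ only in configuration as drawn: 2 of 2 stereo elements differ (all stereocentres are inverted: mirror images); a stereocentre at a saturated ring carbon is drawn S in compound 2 and R in compound 3; a stereocentre at a saturated ring carbon is drawn R in compound 2 and S in compound 3. Their values sit together, a 1.2-fold higher number from compound 2 to compound 3 (0.08 log units; within the scatter), and the fact that compounds 2 and 3 differ only in the configuration as drawn is all that separates them. For the measured compounds named here, the one large step in this assay is a 14-fold lower number from compound 2 to compound 1 (1.14 log units; beyond the scatter), made by dimethylamino in place of amino on a saturated chain carbon, two bonds along the chain from a saturated ring carbon.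

Compound 4 `CN(C)CC[C@@H]1CCC[C@H](c2ccccc2)C1` is not yet measured. It stands to compound 3 as compound 1 stands to compound 2: the change is dimethylamino in place of amino on a saturated chain carbon, two bonds along the chain from a saturated ring carbon, on the same place, the same change. Given that compound 2 gives 138 nM and compound 1 gives 10 nM, a step of like size is expected, with the mirror pair left close as before.

For compound 4 the expected step is a 14-fold lower number from compound 3 to compound 4 (1.14 log units; beyond the scatter), resting on a 14-fold lower number from compound 2 to compound 1 (1.14 log units; beyond the scatter).
Compound 4 is therefore estimated at 12 nM, with a range from 5 nM to 30 nM.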

Compound 4, inhibition constant: 14 nM
Compound 4: the middle estimate sits 1.2-fold (0.07 log units) below what was measured; the range from low to high includes it.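

In this assay the change from amino to dimethylamino carries over to the mirror-image core, with a 12-fold lower number from compound 3 to compound 4 (1.08 log units; beyond the scatter) matching the earlier step: the same change on two cores in this assay, a 14-fold lower number (1.14 log units; beyond the scatter) from compound 2 to compound 1 and a 12-fold lower number (1.08 log units; beyond the scatter) from compound 3 to compound 4, 1.2-fold (0.06 log units) apart, within the scatter of two such steps.
The dimethylamino pair also stays close, at a 1.4-fold higher number from compound 1 to compound 4 (0.15 log units; within the scatter), and only one thing separates these two compounds: the fact that compounds 1 and 4 differ only in the configuration as drawn.
This shows transfer between two mirror-image cores only, so it does not show that the change would carry to a core with different atoms or bonds, nor does it explain the size of the step.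

Open, as far as these compounds go, is whether methylamino or diethylamino in place of dimethylamino would give a step of like size. Also open, from the compounds shown here alone, is how the same change behaves on a longer chain.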